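Isopentyl to 4-fluorophenoxy on the core of compound 1

The compounds below may be only part of what the source reports. "The series", "measured", "known", "first", "only" and "open" are said of these compounds alone.

Compound 1 `COc1ccc(F)cc1CNCCCNc1ccnc2cc(CCC(C)C)ccc12` is measured in a physicochemical assay for acid dissociation, where compound 1 gives 9.47. Compound 2 `COc1cccc(CNCCCNc2ccnc3cc(CCC(C)C)ccc23)c1O` gives 9.47; compound 1 is level with compound 2, the two together the highest of the three numbers. Compound 3 `CC(C)(C)c1ccc(Oc2ccc3c(NCCCNCc4ccco4)ccnc3c2)cc1` gives 9.28, a number within the scatter of compound 1. Among the compounds with values here, the one single-place step, no change at the digits printed from compound 1 to compound 2 (within the scatter), showed no change. Compound 4 `COc1ccc(F)cc1CNCCCNc1ccnc2cc(Oc3ccc(F)cc3)ccc12` differs from compound 1 by 4-fluorophenoxy in place of isopentyl on an aromatic carbon. Within the data shown here, no measured step changes this position; compound 3, which also carries an aryloxy group, sits within the scatter of compound 1. No step beyond the scatter is therefore expected in this assay : a number 0.12 log units lower from compound 1 to compound 4 (within the scatter). Compound 4 is estimated at 9.35, between 9 and 9.7.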

Compound 4, acid dissociation constant: 9.28
Compound 4: middle estimate off by 0.07 log units, on the high side; the range from low to high includes it.
By their numbers in this assay, from the lowest: compounds 3, 4, 1 and 2 (each within the scatter of the next).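

In this assay, within the data shown here, the first step that changes this position alone reads a number 0.19 log units lower from compound 1 to compound 4 (within the scatter). At this aromatic carbon, 4-fluorophenoxy therefore takes the place of isopentyl on the core of compound 1 with no step beyond the scatter, which compound 3 could not show, as it differs from compound 1 in more than one place. No measurement at hand offers an explanation for this reading. Still open, as far as these compounds go, is whether an amine or a carboxylic acid at this position would also stay within the scatter.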